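Acetyl in place of benzyloxy: cytotoxicity working notes

The compounds below may be only part of what the source reports. "The series", "measured", "known", "first", "only" and "open" are said of these compounds alone.

Three analogues on the shared core come first. Compound 1 `CCOC(=O)c1c(-c2cccc(OCC)c2)[nH]c2cc(OC)ccc2c1=O` and compound 2 `CCOC(=O)c1c(-c2cccc(OCC(C)C)c2)[nH]c2cc(OC)ccc2c1=O` and compound 3 `CCOC(=O)c1c(-c2cccc(OCc3ccccc3)c2)[nH]c2cc(OC)ccc2c1=O` differ only in the chain on the oxygen. In an ADME assay on HEK293 cells (Homo sapiens) for cytotoxicity, read by luminescence, with a stated time of 72 h (a lower number here means that less compound is needed, a higher number that more compound is needed for the effect), compound 1 gives > 22000 nM as a limit of the assay. Compound 2 gives > 22000 nM as a limit as well. Compound 3 gives > 22000 nM as a limit too. Compound 3 thus stands at the limit of > 22000 nM in this assay, at which 3 of the 3 values shown sit, and has no number of its own.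

Compound 4 `CCOC(=O)c1c(-c2cccc(C(C)=O)c2)[nH]c2cc(OC)ccc2c1=O` carries acetyl in place of benzyloxy on an aromatic carbon. The measured steps that bear on this change are a step that the two limits leave unreadable from compound 1 to compound 2 and then a step that the two limits leave unreadable from compound 1 to compound 3 and lastly a step that the two limits leave unreadable from compound 2 to compound 3 within that chain. None of the three has a readable size, and none puts acetyl on the ring. No step beyond the scatter can be expected in this assay in either direction. The estimated step is a step that the limit leaves unreadable from compound 3 to compound 4 and carries no firm direction. That expectation rests on compound 3 with its limit of > 22000 nM alone. For compound 4 the expected value is 25000 nM with an estimated range from 12000 nM to 50000 nM and a good chance of another limit.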

Compound 4, half-maximal effective concentration: > 22000 nM
Compound 4: only a limit was reported; the forecaster's own chance of this, stated with the estimate: 80%; the middle value is on the limit's open side.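

No step to compound 4 from compound 1, compound 2 or compound 3 can be read in this assay, because each value is a limit: the limit of > 22000 nM in this assay, at which 4 of the 4 values shown sit.

The compounds shown leave open how the four compounds compare with one another in this assay, and whether any group on this aromatic carbon of the shared core would give a measured value.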